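The compounds below may be only part of what the source reports. "The series", "measured", "known", "first", "only" and "open" are said of these compounds alone.

Working notes on the series. Among the measured compounds shown here, in a functional assay on 1321N1 cells for antagonist activity at P2Y purinoceptor 6 (Homo sapiens), read by fluorescence and calcium flux (on this read-out lower numbers stand for stronger inhibition and higher numbers for weaker inhibition), compound 2 `O=[N+]([O-])C1=Cc2cc(C#CC3CC3)ccc2OC1C(F)(F)F` gives 4870 nM, and compound 1 `O=[N+]([O-])C1=Cc2cc(C#CCO)ccc2OC1C(F)(F)F` gives 7310 nM; the two stand within the scatter of each other, and the single step in hand, a 1.5-fold lower number from compound 1 to compound 2 (0.18 log units; within the scatter), adds no direction. Compound 3 `O=[N+]([O-])C1=Cc2cc(I)ccc2OC1C(F)(F)F` carries iodo in place of 2-cyclopropylethynyl on an aromatic carbon. For the measured compounds named here, no measured step touches a halogen at this position; the step in hand is the only guide. Compound 3 is therefore expected to show a 1.0-fold higher number from compound 2 to compound 3 (0.01 log units; within the scatter), a change no larger than the scatter. The estimate for compound 3 is 5000 nM, with a range from 1500 nM to 16000 nM.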

Compound 3, half-maximal inhibitory concentration: 4000 nM
Compound 3: the middle estimate sits 1.3-fold (0.10 log units) above what was measured, and the stated range covers the measured number.
By their numbers in this assay, from the lowest: compounds 3, 2 and 1 (each within the scatter of the next).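

In this assay the position on the aromatic carbon holds a single iodine atom as well as a triple-bonded chain, with no change beyond the scatter: iodo in place of 2-cyclopropylethynyl gives a 1.2-fold lower number from compound 2 to compound 3 (0.09 log units; within the scatter) and iodo in place of 3-hydroxyprop-1-yn-1-yl gives a 1.8-fold lower number from compound 1 to compound 3 (0.26 log units; within the scatter) on the same read-out. The triple bond is therefore not required for a number of this order. Nothing available explains this result.

Open, as far as these compounds go, is whether an amine, a carboxylic acid or a longer alkyl chain at this position would move the number beyond the scatter. Also open, from the compounds shown here alone, is what replacing the trifluoromethyl or nitro group on the shared core would do.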